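The source may report more compounds than this note shows. Statements on the series, on what has been measured and on what is new or still open speak of the compounds shown alone.

Compound 1 is `COc1ccc(-c2cc(N3CCC(CNS(N)(=O)=O)CC3)ncn2)cc1`; in a functional assay on M21 cells (Homo sapiens) for antiproliferative activity, read by sulforhodamine B assay, with a stated time of 48 h (a lower number here means a stronger inhibitor of growth, a higher number a weaker inhibitor of growth), compound 1 gives only a limit, > 100000 nM.
Compound 2 is `COc1ccccc1-c1cc(N2CCC(CNS(N)(=O)=O)CC2)ncn1`; in this assay compound 2 gives only a limit, > 100000 nM.
Compound 3 is `NS(=O)(=O)NCC1CCN(c2cc(-c3ccccc3Cl)ncn2)CC1`; in this assay compound 3 gives only a limit, > 100000 nM.

Compound 2 therefore stands nowhere in particular among the measured compounds: all three sit at the limit of > 100000 nM in this assay, at which 3 of the 3 values shown sit, so none can be ordered against another. The three steps among them, a step that the two limits leave unreadable from compound 1 to compound 2, a step that the two limits leave unreadable from compound 1 to compound 3 and a step that the two limits leave unreadable from compound 2 to compound 3, are likewise unreadable, since a step between two limits has no size.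

Compound 4 is `COc1ccccc1-c1cc(N2CCC(CCNS(N)(=O)=O)CC2)ncn1`. It differs from compound 2 by (sulfamoylamino)methyl in place of sulfamoylamino on a saturated chain carbon bound to a saturated ring carbon, so the chain between the saturated ring and the sulfamoylamino group grows by one carbon. Among the compounds with values here, no measured step touches that chain; the only steps known change the aryl group, and all of them are unreadable. There is thus no basis to expect compound 4 to move away from the limit in this assay, and the step from compound 2 to compound 4 is expected to be a number no higher from compound 2 to compound 4 (the limit leaves the size open). Compound 4 is estimated at 100000 nM, within 30000 nM to 300000 nM.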

Compound 4, concentration for 50% growth inhibition: 96900 nM
For compound 4 the middle estimate is 1.0-fold (0.01 log units) above the measured one; low and high end bracket the measured number.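

Moving from (sulfamoylamino)methyl to 2-(sulfamoylamino)ethyl yields the only number in this assay that is not a limit, as compound 4 gives 96900 nM. Going by these compounds, the change reads as an at least 1.0-fold lower number from compound 2 to compound 4 (0.01 log units; that floor lies within the scatter), so this floor shows no real gain from the added carbon, and the true size of the step stays open. Growth inhibition on this chain can now be given a number for one compound, while the others remain at a single value:
the limit of > 100000 nM in this assay, at which 3 of the 4 values shown sit.

On these data alone, the steps among compound 1, compound 2 and compound 3 cannot be read, so it remains unknown whether the aryl group matters once the chain is longer. Also open, as far as these compounds go, is what a longer chain, such as 3-(sulfamoylamino)propyl, or an amine or carboxylic acid in place of the sulfamoylamino group, would do in this assay.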